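Acetyl in Place of Furoyl on the Shared Core

The compounds below may be only part of what the source reports. "The series", "measured", "known", "first", "only" and "open" are said of these compounds alone.

Compound 1 `COc1ccc(-c2cnc(NC(=O)c3ccco3)n2C)cc1` is measured in a toxicity assay on THP-1 cells (Homo sapiens) for inhibition; on this read-out higher numbers stand for lower toxicity in this test and lower numbers for higher toxicity in this test. The value of compound 1 in this assay is a limit, not a number: > 100000 nM. One of the two values stands at the limit of > 100000 nM in this assay, at which 1 of the 2 values shown sits. Compound 2 `Cc1ccc(C(=O)Nc2ncc(-c3ccccc3)o2)cc1` gives 26000 nM in this assay. Within the data shown here, no step between measured compounds is recorded. Compound 3 `COc1ccc(-c2cnc(NC(C)=O)n2C)cc1` is not yet measured; it differs from compound 1 by methyl in place of furan-2-yl on a carbonyl carbon, on a carbonyl carbon whose other neighbour is an amide-type nitrogen. In this assay the expected step of a number no higher from compound 1 to compound 3 (the limit leaves the size open) is none beyond the scatter. Compound 3 is expected to give about 100000 nM, within 40000 nM to 300000 nM, likely again as a limit.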

Compound 3, half-maximal cytotoxic concentration: > 100000 nM
Compound 3 ended at the assay's limit; the forecaster's own chance of this, stated with the estimate: 65%; the middle value lies on the limit itself.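

No step can be read between compound 1 and compound 3 in this assay, as both values are limits: the limit of > 100000 nM in this assay, at which 2 of the 3 values shown sit.

Going by these compounds, whether methyl in place of furan-2-yl on a carbonyl carbon changes the read-out at all stays open.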